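Nitro for Trifluoromethoxy on a Thiourea Scaffold

A few compounds are considered here, and "the series" means these few. Any claim that something is new, unique, unknown or untested is made for them only; others in the source may bear on it.

Measured compounds:
compound 1, `CC1(C)CCOc2ccc(NC(=S)Nc3ccc(OC(F)(F)F)cc3)cc21`, 16%
compound 2, `CCC1(CC)CC(CC)(CC)c2cc(NC(=S)Nc3ccc([N+](=O)[O-])cc3)ccc2O1`, 94%
compound 3, `CCC1(CC)CC(C)(C)c2cc(NC(=O)Nc3ccc(C(F)(F)F)cc3)ccc2O1`, 92.4%

Of the compounds shown here, three have been measured in a functional assay on A2780 cells (Homo sapiens) for inhibition, with a stated time of 72 h, tested at 10 uM; on this read-out lower numbers stand for less inhibition of growth and higher numbers for more inhibition of growth at the one concentration tested. Compound 1 gives 16%, the lowest of the three numbers. Its nearest neighbour is compound 3, which gives 92.4%, a gap beyond the scatter; furthest away stands compound 2 with 94%, also beyond the scatter. Going by the values given here, compounds 2 and 3 share a larger core than compound 1 and differ from it in more than one place, so no single step between measured compounds can be isolated.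

Compound 4, `CC1(C)CCOc2ccc(NC(=S)Nc3ccc([N+](=O)[O-])cc3)cc21`, keeps the core and the thiourea of compound 1 and changes only the substituent on the second ring: nitro in place of trifluoromethoxy on an aromatic carbon. Compound 2, the only measured compound bearing a nitro group, gives 94%, but on a different core, so the account relies on an expectation rather than a shown step. The author expects the step from compound 1 to compound 4 in this assay to be upward and beyond the scatter, a number 29 percentage points higher from compound 1 to compound 4 (beyond the scatter), with wide uncertainty. Compound 4 is estimated at 45%, within a range from 15% to 80%.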

Compound 4, percent growth inhibition at one concentration: 19%
Estimate against measurement, compound 4: 26 percentage points above; low and high end bracket the measured number.
By their numbers in this assay, from the lowest: compounds 1 and 4 (each within the scatter of the next); then compounds 3 and 2 (each within the scatter of the next).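

In this assay, placing nitro in place of trifluoromethoxy on an aromatic carbon of the six-membered ring, para to a large group, gives a number 3 percentage points higher from compound 1 to compound 4 (within the scatter), so on the core and thiourea of compound 1 the two groups cannot be told apart at the one concentration tested. Going by these compounds alone, this is the first direct reading at this position: with the rest of the molecule held constant, exchanging these two groups does not separate compound 4 from compound 1, whereas the earlier compounds differed in more than one place and could not isolate the position. Compound 2 also carries nitro, but on a different core, so its value does not speak to this step, and nothing measured here explains why the exchange leaves the read-out within the scatter.

As far as these compounds go, whether an amine or a carboxylic acid at this position would separate from compound 1 remains open. From the compounds shown here alone, it is also open whether the same exchange would read the same way on the core of compound 2 or compound 3, where the numbers stand much higher.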